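Thiophenyl ketone series: from compound 2 to compound 3

The source may report more compounds than this note shows. Statements on the series, on what has been measured and on what is new or still open speak of the compounds shown alone.

Values so far in a functional assay on HUVEC cells (Homo sapiens), read by BrdU incorporation, with a stated time of 72 h; a lower number here means a stronger inhibitor, a higher number a weaker inhibitor:
- compound 1 `Cc1ccc2nc(Cl)c(/C=C/C(=O)c3cc(C)sc3C)cc2c1` gives 229 nM
- compound 2 `Cc1csc(C(=O)/C=C/c2cc3cc(C)ccc3nc2Cl)c1` gives 106 nM

Compound 2 holds the lower of the two numbers. Going by the values given here, the only measured step (a 2.2-fold lower number from compound 1 to compound 2 (0.33 log units; beyond the scatter)) is modest and beyond the scatter.

Next is compound 3 `Cc1ccc2nc(Cl)c(/C=C/C(=O)c3sccc3Br)cc2c1`, which differs from compound 2 in one place (3-bromothiophen-2-yl in place of 4-methylthiophen-2-yl on a carbonyl carbon). Here 3-bromothiophen-2-yl stands in place of 4-methylthiophen-2-yl on a carbonyl carbon. Among the compounds with values here, the one measured step also exchanges the group on that carbonyl carbon, so it is the only guide to how far such an exchange moves this assay. Within the data shown here, no measured compound yet carries bromine, so the direction stays open. Among the measured compounds shown here, a slight lean toward a higher number rests only on compound 2 having the lowest value so far (106 nM). For the measured compounds named here, no step clearly beyond the scatter is expected, and the estimated change is small (a 1.4-fold higher number from compound 2 to compound 3 (0.15 log units; within the scatter)). The estimated value for compound 3 is 150 nM, with an expected range from 60 nM to 400 nM.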

Compound 3, half-maximal inhibitory concentration: 61.9 nM
Compound 3: middle estimate off by 2.4-fold (0.38 log units), on the high side; low and high end bracket the measured number.
By their numbers in this assay, from the lowest: compounds 3 and 2 (each within the scatter of the next); then compound 1.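

In this assay the exchange of 4-methylthiophen-2-yl for 3-bromothiophen-2-yl on a carbonyl carbon gives a 1.7-fold lower number from compound 2 to compound 3 (0.23 log units; within the scatter) and so does not separate these two groups, which shows that a bromine-bearing thiophene can stand at this place without a step beyond the scatter. Measured against 2,5-dimethylthiophen-3-yl, the same bromine-bearing group gives a 3.7-fold lower number from compound 1 to compound 3 (0.57 log units; beyond the scatter) and thus a second step beyond the scatter away from compound 1, so both thiophen-2-yl groups shown part from the single thiophen-3-yl group, although ring attachment and ring substituents change together in these pairs and cannot be told apart. No evidence on why these groups differ in this assay is available.

On these data alone, it remains open whether the thiophene itself matters, as a phenyl or furan-2-yl group on the carbonyl carbon would test, and whether an unsubstituted thiophen-2-yl group would stay with compound 2 and compound 3. The compounds shown also leave open how a saturated chain in place of the double-bonded chain, or an amine in place of the chlorine on the shared core, would read.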